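This account rests on a few compounds, and the source may have more. Where it says the series, first, only, none or still open, it means among the compounds named here.

Compound 1 `COc1cc(-c2cc(/C=C/C(=O)c3ccc(N)cc3)[nH]n2)cc(OC)c1OC`: in a functional assay on UACC-257 cells (Homo sapiens) for inhibition, read by sulforhodamine B assay, with a stated time of 48 h (on this read-out higher numbers stand for lower toxicity in this test and lower numbers for higher toxicity in this test), compound 1 gives 8660 nM.
Compound 2 `COc1ccc(C(=O)/C=C/c2cc(-c3cc(OC)c(OC)c(OC)c3)n[nH]2)cc1OC`: in this assay compound 2 gives 5370 nM.
Compound 3 `COc1cc(-c2cc(/C=C/C(=O)c3ccc(F)c(F)c3)[nH]n2)cc(OC)c1OC`: in this assay compound 3 gives > 100000 nM, which is a limit of the assay rather than a number.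

Among the two numbers, compound 2 holds the lower one, but the step of a 1.6-fold lower number from compound 1 to compound 2 (0.21 log units; within the scatter), so compound 1 and compound 2 cannot be told apart. Compound 4 `COc1cc(C(=O)/C=C/c2cc(-c3cc(OC)c(OC)c(OC)c3)n[nH]2)cc(OC)c1OC` has not yet been measured. It differs from compound 2 by one change: methoxy in place of hydrogen on an aromatic carbon. The measured steps that bear on this part of the molecule are an at least 18-fold higher number from compound 2 to compound 3 (1.27 log units; beyond the scatter) and an at least 11-fold higher number from compound 1 to compound 3 (1.06 log units; beyond the scatter), both large, yet both swap the whole substituted phenyl for a different one, and none adds a methoxy group. Compound 4 keeps both methoxy groups of compound 2 and adds a third, so in this assay the expected step is none beyond the scatter, a 1.1-fold lower number from compound 2 to compound 4 (0.03 log units; within the scatter). Compound 4 is therefore estimated at about 5000 nM, with a range from 1800 nM to 15000 nM.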

Compound 4, concentration lethal to 50% of the cells: 5710 nM
Compound 4: the middle estimate sits 1.1-fold (0.06 log units) below what was measured; low and high end bracket the measured number.
By their numbers in this assay, from the lowest: compounds 2, 4 and 1 (each within the scatter of the next). At a limit, above all of these: compound 3.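

In this assay, adding a methoxy group on the aromatic carbon that is ortho to a methoxy group gives a 1.1-fold higher number from compound 2 to compound 4 (0.03 log units; within the scatter), so this change makes no difference that the assay can read. The earlier steps shown here replaced the whole substituted phenyl, whereas this one isolates a single position on the ring and shows that it accepts a further methoxy group without a readable shift in toxicity. Nothing measured here offers an explanation for this flat result.

A single substituent at one position cannot show whether this flatness is general. A hydroxyl group, an amine or a chlorine atom on the same carbon could behave differently, and so could a longer chain such as ethoxy in place of the new methoxy.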